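Placing an amino acid directly on the side chain of compound 1

This account rests on a few compounds, and the source may have more. Where it says the series, first, only, none or still open, it means among the compounds named here.

Compound 1 `COc1cc2c(cc1O)CCC(C)(CC(=O)O)O2` is the reference here. In an ADME assay on SH-SY5Y cells (Homo sapiens) for cytotoxicity, read by MTT assay, with a stated time of 24 h, tested at 25 uM (a higher number here means a weaker effect of the compound at the concentration tested, a lower number a stronger effect), compound 1 gives 92.5%, the highest of the three numbers in hand. Compound 2 `COc1cc2c(cc1O)CCC(C)(CC(=O)N[C@H](C(=O)O)C(C)C)O2` gives 76.1%, and compound 3 `COc1cc2c(cc1O)CCC(C)(CCNC(=O)C[C@H]1OC(O)[C@H](O)[C@@H](O)[C@@H]1O)O2` gives 87.9%, a value within the scatter of compound 1. Compound 4 `COc1cc2c(cc1O)CCC(C)(CC(N)C(=O)O)O2` has not been measured; it differs from compound 1 by amino(carboxy)methyl in place of carboxy on a saturated chain carbon bound to a saturated ring carbon. Within the data shown here, only the step of a number 16.4 percentage points lower from compound 1 to compound 2 (beyond the scatter) bears on this change, as it too alters the carboxy of compound 1, and it was modest. A small fall or none beyond the scatter is therefore expected for compound 4, estimated at 85% with a range from 70% to 98%. That expected step is a number 7.5 percentage points lower from compound 1 to compound 4 (within the scatter).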

Compound 4, a percentage reported as activity, at one concentration (the size of the read-out at that concentration, not a potency): 88.5%
Estimate against measurement, compound 4: 3.5 percentage points below; measured number inside the range.
By their numbers in this assay, from the lowest: compound 2; then compounds 3, 4 and 1 (each within the scatter of the next).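

In this assay, the step of a number 4 percentage points lower from compound 1 to compound 4 (within the scatter) shows that amino(carboxy)methyl can take the place of carboxy on a saturated chain carbon bound to a saturated ring carbon with no change beyond the scatter. The earlier step of a number 16.4 percentage points lower from compound 1 to compound 2 (beyond the scatter), made on the carbonyl carbon, was the only one on this side chain and went beyond the scatter, so this side chain does not always respond in that way. Nothing measured explains why the two steps differ. Going by these compounds, it remains open whether an amine without the carboxy, a methyl ester of the carboxy, or a longer chain at this place would behave as compound 4 does.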